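The source may hold more compounds than are shown below. What is called first, only, known or untested is meant among the compounds shown, and "the series" means these compounds.

Compound 3 `COc1cccc(NC(=O)CSc2nc3cccnc3[nH]2)c1` is the methoxy member of the series. Going by the values given here, in an assay on isolated protein for inhibition of Ectonucleotide pyrophosphatase/phosphodiesterase family member 1 (Homo sapiens), tested at 10 uM (a higher number here means more inhibition at the concentration tested (going by the name of the read-out), a lower number less inhibition), compound 3 gives 30%, level with the unsubstituted compound 1 `O=C(CSc1nc2cccnc2[nH]1)Nc1ccccc1`, which gives 30%, so that the two together make up the lower end of the three numbers so far. Compound 2 `CC(=O)c1cccc(NC(=O)CSc2nc3cccnc3[nH]2)c1` gives 50% and sits highest. The steps measured are no change at the digits printed from compound 1 to compound 3 (within the scatter), a number 20 percentage points higher from compound 1 to compound 2 (beyond the scatter) and a number 20 percentage points lower from compound 2 to compound 3 (beyond the scatter).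

Compound 4 `CCOC(=O)c1cccc(NC(=O)CSc2nc3cccnc3[nH]2)c1` differs from compound 3 by ethoxycarbonyl in place of methoxy on an aromatic carbon. Among the compounds with values here, no measured step replaces methoxy with ethoxycarbonyl directly. The nearest comparisons are the step from the methoxy to the acetyl analogue, a number 20 percentage points lower from compound 2 to compound 3 (beyond the scatter) read in reverse, and the step that installs acetyl on the bare ring, a number 20 percentage points higher from compound 1 to compound 2 (beyond the scatter). Both say that exchanging methoxy or hydrogen for acetyl at this position raises this assay by a modest amount beyond the scatter. Ethoxycarbonyl is a different group, so the analogy is loose and a smaller gain, or none beyond the scatter, cannot be ruled out.

On that basis compound 4 is expected to show a step of a number 15 percentage points higher from compound 3 to compound 4 (beyond the scatter) in this assay. The estimate for compound 4 is 45%, with a range from 25% to 65%.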

Compound 4, a percentage reported as inhibition, at one concentration (the size of the read-out at that concentration, not a potency): 15%
For compound 4 the middle estimate is 30 percentage points above the measured one; measured number outside the range, below it.
By their numbers in this assay, from the lowest: compound 4; then compounds 1 and 3 (each within the scatter of the next); then compound 2.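

In this assay the position does not simply reward a carbonyl-bearing group, since ethoxy in place of methyl on the carbonyl carbon gives a number 35 percentage points lower from compound 2 to compound 4 (beyond the scatter) and the gain seen with acetyl is more than lost. The ethoxycarbonyl group also falls short of the bare ring and of methoxy, with a number 15 percentage points lower from compound 1 to compound 4 (beyond the scatter) and a number 15 percentage points lower from compound 3 to compound 4 (beyond the scatter); among the compounds shown, a change on this aromatic carbon can therefore lower the number as well as raise it, and compound 4 alone lies beneath the unsubstituted compound 1. No measurement at hand accounts for the difference between the acetyl and ethoxycarbonyl groups.

The compounds shown leave open whether the drop goes with the oxygen of the ethoxycarbonyl group or with the longer chain on its carbonyl carbon, and a propanoyl group or a methoxycarbonyl group in the same place would separate the two. Also open is how a carboxylic acid or a primary amide would read here, as neither group is among these compounds.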